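Swapping the aryl group on the triazole nitrogen

The source may report more compounds than this note shows. Statements on the series, on what has been measured and on what is new or still open speak of the compounds shown alone.

Compound 1 `CC(C)c1ccc(-n2nc(-c3ccc(C(F)(F)F)cc3O)nc2-c2ccccc2O)cc1`: 100%
Compound 2 `CC(C)(C)c1ccc(-n2nc(-c3ccc(C(F)(F)F)cc3O)nc2-c2ccccc2O)cc1`: 77.8%
Compound 3 `Oc1cc(C(F)(F)F)ccc1-c1nc(-c2ccccc2O)n(-c2ccc(Cl)cc2)n1`: 87.3%

These three compounds were tested in a functional assay on PC-12 cells (Rattus norvegicus) for cytotoxicity, read by MTT assay, with stated times of 2 h and 24 h, tested at 5 uM; a lower number here means a weaker effect, a higher number a stronger effect of the compound at the concentration tested. Among them compound 2 has the lowest number; compound 3 is nearest, with a step from compound 2 to compound 3 of a number 9.5 percentage points higher from compound 2 to compound 3 (within the scatter), and compound 1 is furthest, with a step from compound 1 to compound 2 of a number 22.2 percentage points lower from compound 1 to compound 2 (beyond the scatter). The step from compound 1 to compound 3 was a number 12.7 percentage points lower from compound 1 to compound 3 (beyond the scatter).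

Compound 4 `Oc1cc(C(F)(F)F)ccc1-c1nc(-c2ccccc2O)n(-c2ccccc2Cl)n1` has not yet been measured. It differs from compound 2 in one place: 2-chlorophenyl in place of 4-(tert-butyl)phenyl on an aromatic nitrogen. The change sits on an aromatic nitrogen of a five-membered aromatic ring with 3 nitrogen.

The most relevant comparison is the step from compound 2 to compound 3, where a chloro replaced a tert-butyl on an aromatic carbon and the change was a number 9.5 percentage points higher from compound 2 to compound 3 (within the scatter). Compound 4 again carries a chloro in place of the tert-butyl, though within a 2-chlorophenyl group rather than a 4-chlorophenyl one, so the step is expected to be small, if anything a slight rise. For compound 4 the expected value in this assay is 85%, with a likely range from 65% to 100%, which corresponds to an expected step of a number 7.2 percentage points higher from compound 2 to compound 4 (within the scatter).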

Compound 4, a percentage reported as activity, at one concentration (the size of the read-out at that concentration, not a potency): 90.6%
For compound 4 the middle estimate is 5.6 percentage points below the measured one; low and high end bracket the measured number.
By their numbers in this assay, from the lowest: compounds 2, 3, 4 and 1 (each within the scatter of the next, the first and the last beyond it).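

In this assay, the chloro group gives no readable difference between the two placements shown, 2-chlorophenyl and 4-chlorophenyl, with a step of a number 3.3 percentage points higher from compound 3 to compound 4 (within the scatter). Against the two alkyl-substituted aryl groups, the 2-chlorophenyl group behaves differently in each case: the step is a number 12.8 percentage points higher from compound 2 to compound 4 (beyond the scatter), a change that can be read, while the step is a number 9.4 percentage points lower from compound 1 to compound 4 (within the scatter), so these two compounds cannot be told apart. Nothing shown here offers a measured explanation for these numbers.

All four compounds keep the same shared core and differ only in the aryl group on the aromatic nitrogen, and each was read at a single concentration, so the results give the size of the effect at that concentration and not a potency. Going by these compounds, it remains open how this position would respond to a phenyl group carrying an amine or a carboxylic acid, or to a longer chain in place of the isopropyl or tert-butyl group.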